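The source may hold more compounds than are shown below. What is called first, only, known or untested is meant among the compounds shown, and "the series" means these compounds.

Measured in a functional assay on HepG2 cells (Homo sapiens) for inhibition, read by MTT assay, with a stated time of 72 h; a higher number here means a weaker inhibitor, a lower number a stronger inhibitor:
- compound 1 `O=C(Nc1ccccc1)C1CCN(C/C=C/c2ccccc2)CC1`: 90900 nM
- compound 2 `Cc1ccc(NC(=O)C2CCN(C/C=C/c3ccccc3)CC2)cc1`: 33900 nM
- compound 3 `CCCc1ccc(NC(=O)C2CCN(C/C=C/c3ccccc3)CC2)cc1`: 9410 nM

Of these three, compound 3 has the lowest number, 9410 nM, which makes it the strongest inhibitor so far. Compound 4 `CCCCc1ccc(NC(=O)C2CCN(C/C=C/c3ccccc3)CC2)cc1` has not yet been measured. It differs from compound 3 by a single change, methyl in place of hydrogen on a saturated chain carbon, three bonds along the chain from an aromatic carbon, which turns propyl into butyl.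

Among the compounds with values here, two measured steps bear on this. Methyl in place of hydrogen on an aromatic carbon gave a 2.7-fold lower number from compound 1 to compound 2 (0.43 log units; beyond the scatter). Ethyl in place of hydrogen on a saturated chain carbon bound to an aromatic carbon gave a 3.6-fold lower number from compound 2 to compound 3 (0.56 log units; beyond the scatter). Across these three compounds, a longer chain goes with a lower number, and none goes against this. Methyl is a smaller addition than the ethyl behind a 3.6-fold lower number from compound 2 to compound 3 (0.56 log units; beyond the scatter), so a smaller lowering is expected in this assay, perhaps close to the scatter. The expected step is a 1.7-fold lower number from compound 3 to compound 4 (0.23 log units; within the scatter). For compound 4 the estimated value is 5500 nM, with an expected range from 2500 nM to 12000 nM.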

Compound 4, half-maximal inhibitory concentration: 4320 nM
For compound 4 the middle estimate is 1.3-fold (0.10 log units) above the measured one, within the range that was stated.
By their numbers in this assay, from the lowest: compound 4; then compound 3; then compound 2; then compound 1.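

Turning propyl into butyl still lowers the number in this assay, with a 2.2-fold lower number from compound 3 to compound 4 (0.34 log units; beyond the scatter) beyond the scatter, so the lowering seen up to propyl continues for at least one more chain length. Within the data shown here, compound 4 is the strongest inhibitor of the four, and the longer comparisons give a 7.8-fold lower number from compound 2 to compound 4 (0.89 log units; beyond the scatter) and a 21-fold lower number from compound 1 to compound 4 (1.32 log units; beyond the scatter), the second being the only large step in the set. All four compounds now fall in order of chain length, from no chain through methyl, propyl and butyl, and none goes against that order.

Nothing measured here explains why the number falls as the chain grows. Going by these compounds, whether a longer chain such as pentyl or hexyl lowers it further, or a branched tert-butyl group or an amine in this place fits the same order, remains open.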